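The source may report more compounds than this note shows. Statements on the series, on what has been measured and on what is new or still open speak of the compounds shown alone.

Among the compounds with values here, compound 1 `Cc1cc(Cl)ccc1NC(=O)Nc1nc(Sc2c[nH]c3ccccc23)cc(N2CCN(Cc3ccccc3)CC2)n1` is one of two compounds measured in a functional assay on MDA-MB-231 cells (Homo sapiens) for inhibition, with a stated time of 72 h; on this read-out lower numbers stand for stronger inhibition and higher numbers for weaker inhibition. In this assay compound 1 gives 22100 nM, the highest of the two numbers. The other compound, compound 2 `O=C(Nc1ccccc1)Nc1nc(Sc2c[nH]c3ccccc23)cc(N2CCCC2)n1`, gives 7890 nM in this assay, a lower number that lies beyond the usual scatter. Within the data shown here, compound 2 differs from compound 1 in more than one place, so the two values show only that compound 2 inhibits more strongly, not which part of the structure carries the difference.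

Compound 3 `COc1ccc(NC(=O)Nc2nc(Sc3c[nH]c4ccccc34)cc(N3CCN(Cc4ccccc4)CC3)n2)cc1` differs from compound 1 in a single place: 4-methoxyphenyl in place of 4-chloro-2-methylphenyl on an amide-type nitrogen. Among the measured compounds shown here, no measured pair isolates this change, so there is no direct guide to its size. Because compound 2 gives 7890 nM with a plain phenyl on that nitrogen, a step toward a somewhat lower number is expected, though a step within the scatter is also plausible. The expected step from compound 1 to compound 3 is a 1.5-fold lower number from compound 1 to compound 3 (0.17 log units; within the scatter). Compound 3 is therefore estimated at 15000 nM in this assay, within a range of 5000 nM to 50000 nM.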

Compound 3, half-maximal inhibitory concentration: 8920 nM
Beside the measured number, compound 3's estimate is 1.7-fold (0.23 log units) above it, and the stated range covers the measured number.
By their numbers in this assay, from the lowest: compounds 2 and 3 (each within the scatter of the next); then compound 1.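

With the rest of the molecule unchanged, putting 4-methoxyphenyl in place of 4-chloro-2-methylphenyl on the amide-type nitrogen gives a 2.5-fold lower number from compound 1 to compound 3 (0.39 log units; beyond the scatter) in this assay. Compound 1 and compound 2 differ in more than one place, whereas this single-place step shows that the group on this nitrogen can by itself move the number, though only modestly. No measurement shown here explains the step.

The change removes a chlorine and a methyl group and adds a methoxy group in one move, so the part each plays remains unresolved. Also open, on these data alone, is where a plain 4-chlorophenyl, a 2-methylphenyl or a 4-aminophenyl group on this nitrogen would fall relative to compound 1 and compound 3 with the rest of the structure kept the same.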